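Trifluoromethyl in place of methoxy on an aryl ring

The source may report more compounds than this note shows. Statements on the series, on what has been measured and on what is new or still open speak of the compounds shown alone.

The two measured compounds are read in an assay on isolated protein for inhibition of serine/threonine-protein kinase PLK1 (Homo sapiens), read by radiometric assay and 33P incorporation, with a stated time of 40 min, tested at 20 uM, in the presence of a further agent that is not named here; a higher number here means more inhibition at the concentration tested (going by the name of the read-out), a lower number less inhibition. Compound 1 `CCNc1cc(-c2ccc(NC(=O)Nc3ccc(C(F)(F)F)cc3)cc2C)ccn1` gives 54.8% in this assay. Compound 2 `CCNc1cc(-c2ccc(NC(=O)Nc3ccc(OC)cc3)cc2C(F)(F)F)ccn1` gives 62.1%. Among the measured compounds shown here, on these two numbers compound 2 stands highest, yet its only neighbour is compound 1 at a value a few points lower, a gap that falls within the usual scatter, so the two cannot be ranked against each other. For the measured compounds named here, no step between measured compounds that differ in a single place is available in this set.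

Compound 3 `CCNc1cc(-c2ccc(NC(=O)Nc3ccc(C(F)(F)F)cc3)cc2C(F)(F)F)ccn1` differs from compound 2 in one place: trifluoromethyl in place of methoxy on an aromatic carbon. Compound 1 already carries the trifluoromethyl group that enters here and gives 54.8% in this assay, so the group is known to be compatible with inhibition of the same order. The step from compound 2 to compound 3 is therefore expected to be small, a number 4.1 percentage points lower from compound 2 to compound 3 (within the scatter), not beyond the scatter in either direction. For compound 3 an inhibition of 58% is estimated, with a range from 42% to 74%.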

Compound 3, a percentage reported as inhibition, at one concentration (the size of the read-out at that concentration, not a potency): 82.9%
Estimate against measurement, compound 3: 24.9 percentage points below; measured number above the stated range.
By their numbers in this assay, from the lowest: compounds 1 and 2 (each within the scatter of the next); then compound 3.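

In this assay, replacing methoxy with trifluoromethyl para to a large group gives a number 20.8 percentage points higher from compound 2 to compound 3 (beyond the scatter), and replacing methyl with trifluoromethyl on the other aromatic carbon gives a number 28.1 percentage points higher from compound 1 to compound 3 (beyond the scatter). Compound 1 and compound 2 each carry a single trifluoromethyl group and lie within the scatter of each other, so they gave no sign that compound 3, which carries the group in both places, would stand clear of both. The number in this assay is therefore higher with trifluoromethyl than with methoxy at the place para to a large group, at least when the other aromatic carbon also carries trifluoromethyl. Nothing available here accounts for this gain.

The compounds shown leave open whether the same change would give a similar step with methyl on the other aromatic carbon, since each comparison here rests on a single pair. They also leave open how a chlorine, a nitrile or an amine would compare at either place, and, with only one tested concentration, how the three compounds differ in potency.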